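From Dimethylamino to Piperidin-1-yl on a Shared Core

The source may hold more compounds than are shown below. What is called first, only, known or untested is meant among the compounds shown, and "the series" means these compounds.

In an ADME assay on L6 cells (Rattus norvegicus) for cytotoxicity (on this read-out higher numbers stand for weaker inhibition and lower numbers for stronger inhibition), compound 1 (`O=C(CCN1CCCC1)OC1CC2(N3CCCCC3)CC(c3ccccc3)C1C(c1ccccc1)C2`) gives 12500 nM and compound 2 (`CN(C)C12CC(OC(=O)CCN3CCC(O)CC3)C(C(c3ccccc3)C1)C(c1ccccc1)C2`) gives 89200 nM as the higher of the two numbers, a gap beyond the usual scatter. Among the measured compounds shown here, no pair of measured compounds differs in one place only, so the size of any single structural change remains unknown.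

Compound 3 (`O=C(CCN1CCC(O)CC1)OC1CC2(N3CCCCC3)CC(c3ccccc3)C1C(c1ccccc1)C2`) departs from compound 2 in one place: piperidin-1-yl in place of dimethylamino on a saturated ring carbon with piperidin-1-yl in place of dimethylamino on a saturated ring carbon. For the measured compounds named here, the only guide is compound 1, which also carries piperidin-1-yl on that carbon and stands at 12500 nM in the same read-out. With a single such compound the evidence is thin, and it suggests a shift towards stronger inhibition rather than proving one. In this assay the expected change is a 3.0-fold lower number from compound 2 to compound 3 (0.47 log units; beyond the scatter) as an estimated step that lies modestly beyond the scatter. Compound 3 is expected at about 30000 nM with an estimated range from 12000 nM to 75000 nM for its measurement.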

Compound 3, half-maximal inhibitory concentration: 28500 nM
The estimate for compound 3 lay 1.1-fold (0.02 log units) above the measured number; the range from low to high includes it.
By their numbers in this assay, from the lowest: compound 1; then compound 3; then compound 2.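

In this assay, piperidin-1-yl in place of dimethylamino on a saturated ring carbon, with the rest of the molecule unchanged, gives a 3.1-fold lower number from compound 2 to compound 3 (0.50 log units; beyond the scatter), so the size of this change can now be read by itself rather than inferred from compounds that also differ elsewhere. Compound 3 also separates a second change: with piperidin-1-yl held on the ring carbon, 4-hydroxypiperidin-1-yl in place of pyrrolidin-1-yl on a saturated chain carbon, two bonds along the chain from a carbonyl carbon, gives a 2.3-fold higher number from compound 1 to compound 3 (0.36 log units; beyond the scatter), so the two single changes move the number in opposite directions. Nothing measured here accounts for either step.

On these data alone, these two steps each rest on one pair of compounds, so it remains open whether the step at the ring carbon would keep its size with pyrrolidin-1-yl on the chain carbon. As far as these compounds go, it is equally open how morpholin-4-yl or a primary amine on that ring carbon would compare with dimethylamino and piperidin-1-yl.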